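Phenylpiperazine amide chalcone-triazole series: a nitro variant

A few compounds are considered here, and "the series" means these few. Any claim that something is new, unique, unknown or untested is made for them only; others in the source may bear on it.

Measured so far:
- compound 1 `CCCCCCCCn1cc(/C=C/C(=O)c2ccc(NC(=O)CN3CCN(c4ccccc4)CC3)cc2)nn1`: 33800 nM
- compound 2 `CCCCCCCCCCn1cc(/C=C/C(=O)c2ccc(NC(=O)CN3CCN(c4ccccc4)CC3)cc2)nn1`: 59100 nM
- compound 3 `O=C(CN1CCN(c2ccccc2)CC1)Nc1ccc(C(=O)/C=C/c2cn(Cc3ccc(Br)cc3)nn2)cc1`: 79700 nM

All three numbers come from a functional assay on HeLa cells (Homo sapiens) for inhibition, read by MTT assay; on this read-out lower numbers stand for stronger inhibition and higher numbers for weaker inhibition. Compound 1 gives the lowest number of the three, but the gap to compound 2, a 1.7-fold higher number from compound 1 to compound 2 (0.24 log units; within the scatter), sits within the scatter, so the two cannot be ordered. The gap to compound 3, a 2.4-fold higher number from compound 1 to compound 3 (0.37 log units; beyond the scatter), is beyond the scatter, though modest. From compound 2 to compound 3 the step is a 1.3-fold higher number from compound 2 to compound 3 (0.13 log units; within the scatter), again within the scatter. Every measured step in this set changes only the group on the triazole nitrogen; the phenylpiperazine end of the shared core is the same in all three.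

Compound 4 `CCCCCCCCn1cc(/C=C/C(=O)c2ccc(NC(=O)CN3CCN(c4ccc([N+](=O)[O-])cc4)CC3)cc2)nn1` differs from compound 1 at that untouched end: nitro in place of hydrogen on an aromatic carbon. For the measured compounds named here, no measured step touches this part of the molecule, so nothing in the set speaks to the size or direction of the change. The closest guidance is that the set as a whole spans a narrow band of numbers in this assay despite sizeable changes elsewhere. The working expectation is therefore no step beyond the scatter, so for compound 4 the estimated step is a 1.1-fold lower number from compound 1 to compound 4 (0.02 log units; within the scatter). Compound 4 is expected at 32000 nM, with a range from 9000 nM to 110000 nM, the width reflecting the absence of any direct precedent.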

Compound 4, half-maximal inhibitory concentration: 30200 nM
The estimate for compound 4 lay 1.1-fold (0.03 log units) above the measured number; low and high end bracket the measured number.
By their numbers in this assay, from the lowest: compounds 4, 1, 2 and 3 (each within the scatter of the next, the first and the last beyond it).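

In this assay, for the compounds shown here, the first change at the phenylpiperazine end of the shared core, nitro in place of hydrogen on an aromatic carbon para to a large group, gives a 1.1-fold lower number from compound 1 to compound 4 (0.05 log units; within the scatter). Going by these compounds alone, this end of the molecule, untested by the earlier steps, therefore accepts phenyl to 4-nitrophenyl with the group on the triazole nitrogen held as in compound 1, and the read-out does not separate the two compounds. This is a single pair with a single substituent, and the compounds shown offer no measurement that would explain the result.

From the compounds shown here alone, it remains open whether an amine, a carboxylic acid or a methoxy group at the same place would also stay within the scatter, and whether a nitro group on another carbon of that ring would do the same. Going by these compounds, it is equally open whether phenyl to 4-nitrophenyl would read the same way with the longer chain of compound 2 or the 4-bromophenyl-bearing group of compound 3 on the triazole nitrogen.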